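Acyl variation on the shared core: notes toward compound 4

The compounds below may be only part of what the source reports. "The series", "measured", "known", "first", "only" and "open" are said of these compounds alone.

Measured compounds in a functional assay on DU-145 cells (Homo sapiens) for cytotoxicity, read by MTT assay; a higher number here means a weaker inhibitor, a lower number a stronger inhibitor:
Compound 1, `CC(C)=CC[C@@H](OC(=O)c1ccoc1)C1=CC(=O)c2c(O)ccc(O)c2C1=O`, gives > 100000 nM, which is a limit of the assay and not a number.
Compound 2, `CCC(CO[C@H](CC=C(C)C)C1=CC(=O)c2c(O)ccc(O)c2C1=O)OC(C)=O`, gives 25400 nM.
Compound 3, `CC(C)=CC[C@@H](OC(=O)CCO)C1=CC(=O)c2c(O)ccc(O)c2C1=O`, gives 55300 nM.

Compound 3 holds the highest of the two numbers shown. Its nearest neighbour is compound 2, the step being a 2.2-fold higher number from compound 2 to compound 3 (0.34 log units; beyond the scatter). Compound 1 rests at a limit, (the limit of > 100000 nM in this assay, at which 1 of the 3 values shown sits), so its step to compound 3 is only a floor: an at least 1.8-fold lower number from compound 1 to compound 3 (0.25 log units; that floor lies within the scatter).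

Compound 4, `CCCC(C)(O)CC(=O)O[C@H](CC=C(C)C)C1=CC(=O)c2c(O)ccc(O)c2C1=O`, differs from compound 3 by 1-hydroxy-1-methylbutyl in place of hydroxymethyl on a saturated chain carbon bound to a carbonyl carbon. The hydroxyl stays; only carbons are added on the acyl side. Of the measured steps, an at least 1.8-fold lower number from compound 1 to compound 3 (0.25 log units; that floor lies within the scatter) is the one that also alters the acyl group, and it is a floor that stays within the scatter; an at least 3.9-fold lower number from compound 1 to compound 2 (0.59 log units; beyond the scatter) and a 2.2-fold higher number from compound 2 to compound 3 (0.34 log units; beyond the scatter) each swap ester for ether and read modest. Among the measured compounds shown here, no measured step tests chain growth on the acyl group itself. The expected step is therefore small, if anything a slightly lower number, a 1.4-fold lower number from compound 3 to compound 4 (0.14 log units; within the scatter), leaning on compound 2 at 25400 nM as the lower bulkier neighbour. In this assay compound 4 is estimated at 40000 nM, between 12000 nM and 130000 nM.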

Compound 4, half-maximal inhibitory concentration: 75000 nM
Estimate against measurement, compound 4: 1.9-fold (0.27 log units) below, and the stated range covers the measured number.
By their numbers in this assay, from the lowest: compound 2; then compounds 3 and 4 (each within the scatter of the next). At a limit, above all of these: compound 1.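

In this assay, replacing hydroxymethyl with 1-hydroxy-1-methylbutyl on a saturated chain carbon bound to a carbonyl carbon keeps the hydroxyl and adds carbons to the acyl chain, and the two values stay within the scatter of each other (a 1.4-fold higher number from compound 3 to compound 4 (0.13 log units; within the scatter)). Among the compounds shown here, this is the first direct test of chain growth on the acyl group, and for this one pair the added carbons give no readable difference. The 2-acetoxybutyl group of compound 2 still holds the lower number against the longer hydroxy acyl group, a modest step (a 3.0-fold higher number from compound 2 to compound 4 (0.47 log units; beyond the scatter)), while compound 1 sits at a limit, so its step to compound 4 (an at least 1.3-fold lower number from compound 1 to compound 4 (0.12 log units; that floor lies within the scatter)) cannot be read as a size: the limit of > 100000 nM in this assay, at which 1 of the 4 values shown sits.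

Going by these compounds, compounds 3 and 4 both carry the hydroxyl, so its own contribution stays open, and an unsubstituted alkyl chain or a carboxylic acid at that place would address it. Also open, on these data alone, is whether a longer chain, or an amine in place of the hydroxyl, would give a step beyond the scatter on this acyl group.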